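Dichloro substitution on two benzyl-purine isomers

A few compounds are considered here, and "the series" means these few. Any claim that something is new, unique, unknown or untested is made for them only; others in the source may bear on it.

Measured compounds in a functional assay on PC-3 cells (Homo sapiens) for cytotoxicity, read by sulforhodamine B assay, with a stated time of 48 h; a lower number here means a stronger inhibitor of growth, a higher number a weaker inhibitor of growth:
- compound 1, `ClCc1cccc(Cn2cnc3c(Cl)ncnc32)c1`: 4160 nM
- compound 2, `ClCc1cccc(Cn2cnc3c(Cl)nc(Cl)nc32)c1`: 2390 nM
- compound 3, `ClCc1ccccc1Cn1cnc2ncnc(Cl)c21`: 4460 nM

Compounds 1 and 2 share one core; compound 3 carries the same atoms joined differently, and the difference between the two cores is not broken down here. Compounds 1 and 3 sit within the scatter of each other in this assay, so no order between them is claimed.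

The change from compound 1 to compound 2 is chloro in place of hydrogen on an aromatic carbon. It gave a 1.7-fold lower number from compound 1 to compound 2 (0.24 log units; within the scatter).

Compound 4, `ClCc1ccccc1Cn1cnc2nc(Cl)nc(Cl)c21`, is not yet measured. It arises from compound 3 by chloro in place of hydrogen on an aromatic carbon. The place of the change reads the same word for word as in the first pair, so this is the same change made on the other core; it occurs twice among the compounds shown.

Among the compounds with values here, for compound 4 the expected step in this assay is a 1.7-fold lower number from compound 3 to compound 4 (0.23 log units; within the scatter), resting on the single earlier step of a 1.7-fold lower number from compound 1 to compound 2 (0.24 log units; within the scatter), which was itself within the scatter. Compound 4 is accordingly estimated at 2600 nM, with a range from 1200 nM to 5600 nM.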

Compound 4, concentration for 50% growth inhibition: 750 nM
For compound 4 the middle estimate is 3.5-fold (0.54 log units) above the measured one, outside the stated range (below it).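

In this assay, chloro in place of hydrogen on an aromatic carbon gives a 5.9-fold lower number from compound 3 to compound 4 (0.77 log units; beyond the scatter), a step beyond the scatter on the core of compound 3. The same change therefore does not carry over at one size from the core of compound 1 to the core of compound 3: the same change on two cores in this assay, a 1.7-fold lower number (0.24 log units; within the scatter) from compound 1 to compound 2 and a 5.9-fold lower number (0.77 log units; beyond the scatter) from compound 3 to compound 4, 3.4-fold (0.53 log units) apart, beyond the scatter of two such steps. This shows that the size of the step differed on these two cores, but with one pair per core it does not show why, or what size the step would take on any further core.

Still open, as far as these compounds go, is whether an amine or a methoxy group on the same carbon, between two ring nitrogen atoms, would give a step that also differs from one core to the other. Also open, from the compounds shown here alone, is whether the difference in step size would persist with a carboxylic acid or a longer chain in place of the chloro group.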